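Adding a Second Trifluoromethyl Group to Compound 3

The source may hold more compounds than are shown below. What is called first, only, known or untested is meant among the compounds shown, and "the series" means these compounds.

Of the compounds shown here, three have so far been measured in a functional assay on PC-3 cells (Homo sapiens) for cytotoxicity, read by MTT assay, with a stated time of 72 h; on this read-out lower numbers stand for stronger inhibition and higher numbers for weaker inhibition. Compound 1 `CC1=CCCC(C)(C)C1/C=C/C(=O)/C=C/c1ccccc1F` gives 4800 nM in this assay. Compound 2 `CC1=CCCC(C)(C)C1/C=C/C(=O)/C=C/c1cc(C(F)(F)F)ccc1F` gives 3100 nM in this assay, and the step of a 1.5-fold lower number from compound 1 to compound 2 (0.19 log units; within the scatter) goes with the change (trifluoromethyl in place of hydrogen on an aromatic carbon). Compound 3 `CC1=C(/C=C/C(=O)/C=C/c2cccc(C(F)(F)F)c2)C(C)(C)CCC1O` gives 3500 nM in this assay; the difference between the core of compound 3 and the core of compound 1 is not broken down here, so only their two values can be set side by side, and these lie within the scatter of each other.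

Compound 4 `CC1=C(/C=C/C(=O)/C=C/c2cc(C(F)(F)F)ccc2C(F)(F)F)C(C)(C)CCC1O` has not yet been measured. It differs from compound 3 by trifluoromethyl in place of hydrogen on an aromatic carbon. Among the compounds with values here, this is the same kind of change as the one from compound 1 to compound 2, but not the same: in compound 2 the entering group sits meta to a large group and para to a fluoro group, whereas in compound 4 it sits ortho to a large group and para to a trifluoromethyl group.

Resting on the step of a 1.5-fold lower number from compound 1 to compound 2 (0.19 log units; within the scatter), compound 4 is expected to give 3000 nM in this assay. The estimate means an expected step of a 1.2-fold lower number from compound 3 to compound 4 (0.07 log units; within the scatter), which would stay within the scatter. For compound 4 the expected range runs from 1200 nM to 7500 nM.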

Compound 4, half-maximal inhibitory concentration: 1900 nM
Compound 4: middle estimate off by 1.6-fold (0.20 log units), on the high side; the measured number falls inside the stated range.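

In this assay, trifluoromethyl in place of hydrogen on an aromatic carbon goes with a 1.8-fold lower number from compound 3 to compound 4 (0.27 log units; within the scatter), so this step on its own does not stand clear of the usual variation between repeated measurements. Set beside the earlier step, the change reads alike on the two cores: the same change on two cores in this assay, a 1.5-fold lower number (0.19 log units; within the scatter) from compound 1 to compound 2 and a 1.8-fold lower number (0.27 log units; within the scatter) from compound 3 to compound 4, 1.2-fold (0.08 log units) apart, within the scatter of two such steps This shows only that the two steps cannot be told apart; it does not show that the change lowers the number on either core, and two pairs do not make a rule for the series, the more so as the entering group in compound 4 sits ortho to a large group and para to a trifluoromethyl group, a different setting from the one it has in compound 2.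

The compounds shown leave open whether a step beyond the scatter could be reached at this place on the aromatic ring with a group of another kind, such as an amine or a carboxylic acid. They also leave open whether the hydroxyl group on the core of compound 3 and compound 4 matters to the size of the step, since no pair shown differs in that group alone.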